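This account rests on a few compounds, and the source may have more. Where it says the series, first, only, none or still open, it means among the compounds named here.

Compound 2 `CCCNC(=O)CC1CCc2cc(OC)c(OC)cc21` is the starting point of this step. In a functional assay on the whole organism (strain Wistar) for inhibition, with Rattus norvegicus as the target, read by paw edema, with stated times of 60 min and 1 h, at a dose of 100 mg/kg by the oral route (a lower number here means less inhibition, a higher number more inhibition at the dose given (going by the name of the read-out)), compound 2 gives 18.8%. Compound 1 `COc1cc2c(cc1OC)C(CC(N)=O)CC2` gives 18.8% in the same test, and compound 3 `COc1cc2c(cc1OC)C(CC(=O)NC1CCCCC1)CC2` gives 50%. Compound 2 and compound 1 stand level, together the lowest of the three numbers, with no change at the digits printed from compound 1 to compound 2 (within the scatter); compound 3 stands well apart from both, with a number 31.2 percentage points higher from compound 2 to compound 3 (beyond the scatter) and a number 31.2 percentage points higher from compound 1 to compound 3 (beyond the scatter).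

Compound 4 `COc1cc2c(cc1OC)C(CC(=O)NCc1ccccc1)CC2` has not yet been measured. It differs from compound 2 in one place: phenyl in place of ethyl on a saturated chain carbon bound to an amide-type nitrogen. For the measured compounds named here, the steps that bear on this are the two that alter the group on the amide-type nitrogen. Putting propyl where hydrogen was left the number unchanged, while putting cyclohexyl where propyl was brought a large rise. Going by the values given here, the change to compound 4 brings in a six-membered aromatic ring of carbon only, six heavy atoms entering where two leave, so it resembles the cyclohexyl step in adding a ring, though no measured compound carries an aromatic ring at this place. A rise from compound 2 to compound 4 of a number 16.2 percentage points higher from compound 2 to compound 4 (beyond the scatter) is therefore expected, smaller than the cyclohexyl step and uncertain in size. Compound 4 is estimated at 35%, with a range from 15% to 55%.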

Compound 4, a percentage reported as inhibition, in the whole organism at one dose (the size of the read-out at that dose, not a potency): 18.8%
Estimate against measurement, compound 4: 16.2 percentage points above; the measured number falls inside the stated range.
By their numbers in this assay, from the lowest: compounds 1, 2 and 4 (each within the scatter of the next); then compound 3.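

In this assay, bringing in an aromatic ring on the saturated chain carbon bound to the amide-type nitrogen gives no change at the digits printed from compound 2 to compound 4 (within the scatter), and the comparison with the unsubstituted amide gives no change at the digits printed from compound 1 to compound 4 (within the scatter), so a ring in this group is not enough on its own to raise the number. The benzyl group also separates clearly from the cyclohexyl group, with a number 31.2 percentage points lower from compound 3 to compound 4 (beyond the scatter), which means that among these four compounds only the cyclohexyl amide stands apart, while hydrogen, propyl and benzyl on the nitrogen give matching numbers. Nothing available here explains why the cyclohexyl amide behaves differently.

Compound 3 and compound 4 differ both in the kind of ring and in how it is attached, since the benzyl group holds its ring one chain carbon away from the nitrogen, so these compounds cannot say which of the two matters. A cyclohexylmethyl group or a phenyl group on the amide-type nitrogen would pull those two apart, and a cyclopentyl group would show whether the rise is tied to the six-membered saturated ring.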